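The source may report more compounds than this note shows. Statements on the series, on what has been measured and on what is new or still open speak of the compounds shown alone.

Measured in an assay on isolated protein for binding affinity to Adrenergic receptor alpha-1 (Rattus norvegicus), read by radioligand binding; on this read-out lower numbers stand for stronger inhibition and higher numbers for weaker inhibition:
compound 1 `COc1ccc2c(c1)C(CCCN1CCN(c3ccccn3)CC1)=CCC2` gives 152 nM
compound 2 `COc1ccc2c(c1)C(NCCN1CCN(c3ccccc3OC)CC1)CCC2` gives 1960 nM
compound 3 `COc1ccc2c(c1)C(CCCN1CCN(c3cccc(C(F)(F)F)c3)CC1)CCC2` gives 2930 nM

Compound 1 stands lowest of the three numbers; compound 2 lies nearest to it, compound 3 furthest, and both gaps from compound 1 lie beyond the scatter. Going by the values given here, no step between two measured compounds that differ in one place is available, so the three values do not isolate any single change.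

The step from compound 1 to compound 4 `COc1ccc2c(c1)C(CCCN1CCN(c3ccccc3OC)CC1)=CCC2` is 2-methoxyphenyl in place of pyridin-2-yl on an amine nitrogen in a ring. Among the compounds with values here, compound 2 also carries a 2-methoxyphenyl on the ring nitrogen, but differs from compound 4 in more than one place; the value of compound 2, 1960 nM, therefore sets no direction for this step.

For compound 4 a step of moderate size toward a lower number is expected, a 1.9-fold lower number from compound 1 to compound 4 (0.28 log units; within the scatter), though a result within the scatter of compound 1 cannot be excluded. In this assay compound 4 is estimated at 80 nM, with a range from 20 nM to 400 nM.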

Compound 4, half-maximal inhibitory concentration: 24.5 nM
Compound 4: middle estimate off by 3.3-fold (0.51 log units), on the high side; the measured number falls inside the stated range.
By their numbers in this assay, from the lowest: compound 4; then compound 1; then compounds 2 and 3 (each within the scatter of the next).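

Going by these compounds alone, with the rest of compound 1 unchanged, 2-methoxyphenyl in place of pyridin-2-yl on an amine nitrogen in a ring gives, in this assay, a 6.2-fold lower number from compound 1 to compound 4 (0.79 log units; beyond the scatter), the first change that can be read at a single place and evidence that the read-out responds to the group on this ring nitrogen. The two groups match in hydrogen-bond donor count, hydrogen-bond acceptor count and net charge, so those counts do not separate them. Nothing at hand explains the size or direction of this step.

As far as these compounds go, whether the same change holds on the core of compound 3 stays open. A plain phenyl, 2-ethoxyphenyl or 2-chlorophenyl on the same ring nitrogen would show whether the methoxy group itself matters or the carbon-only aromatic ring is enough.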